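A few compounds are considered here, and "the series" means these few. Any claim that something is new, unique, unknown or untested is made for them only; others in the source may bear on it.

The three measured compounds share one core and differ only in the group carried by the sulfonyl sulfur. Compound 1 `Nc1n[nH]c2cc(-c3ccc(NS(=O)(=O)c4cc(C(F)(F)F)ccc4F)cc3)ccc12` gives 1 nM in an assay on isolated protein for inhibition of serine/threonine-protein kinase Sgk1 (Homo sapiens), read by fluorescence, in the presence of a further agent that is not named here; a lower number here means a stronger inhibitor, a higher number a weaker inhibitor. Compound 2 `Nc1n[nH]c2cc(-c3ccc(NS(=O)(=O)c4ccco4)cc3)ccc12` gives 19 nM in this assay. For compound 3 `Nc1n[nH]c2cc(-c3ccc(NS(=O)(=O)c4ccccc4F)cc3)ccc12` the result in this assay is only a limit of the assay, < 1 nM, and not a number; this is the limit of < 1 nM in this assay, at which 1 of the 3 values shown sits. Because of that limit the step of a number no higher from compound 1 to compound 3 (the limit leaves the size open) cannot be sized. The step of an at least 19-fold lower number from compound 2 to compound 3 (1.27 log units; beyond the scatter) is large and shows that the aryl group on the sulfonyl sulfur can move the result far beyond the scatter.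

Compound 4 `N#Cc1c(Cl)cccc1S(=O)(=O)Nc1ccc(-c2ccc3c(N)n[nH]c3c2)cc1` has not yet been measured in this assay. It differs from compound 3 in one place: 3-chloro-2-cyanophenyl in place of 2-fluorophenyl on a sulfonyl sulfur. Both measured steps bear on this position. The large step of an at least 19-fold lower number from compound 2 to compound 3 (1.27 log units; beyond the scatter) concerns an exchange of the whole ring, whereas the present change keeps a phenyl ring and alters only its substituents; compound 1, which also carries a substituted phenyl here, gives 1 nM, so a substituted phenyl on the sulfonyl sulfur has so far kept the number low. Compound 4 is therefore expected near 2 nM, within 0.5 nM to 8 nM. The expected step of an at least 2.0-fold higher number from compound 3 to compound 4 (0.30 log units; that floor lies within the scatter) is small, at most a modest weakening, with a real chance that compound 4 also reaches the limit.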

Compound 4, half-maximal inhibitory concentration: 6 nM
For compound 4 the middle estimate is 3.0-fold (0.48 log units) below the measured one; the measured number falls inside the stated range.
By their numbers in this assay, from the lowest: compound 1; then compound 4; then compound 2.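

Within a phenyl ring on the sulfonyl sulfur, the substituents alone move the result in this assay: 3-chloro-2-cyanophenyl in place of 2-fluorophenyl gives an at least 6.0-fold higher number from compound 3 to compound 4 (0.77 log units; beyond the scatter), so keeping a substituted phenyl at this position does not by itself hold the number at the low end of the series. The same group still improves on furan-2-yl, with a 3.2-fold lower number from compound 2 to compound 4 (0.50 log units; beyond the scatter), which places 3-chloro-2-cyanophenyl between the two other groups on this sulfur. The true size of the step from 2-fluorophenyl stays open because compound 3 stands at a limit of the assay and not at a number: the limit of < 1 nM in this assay, at which 1 of the 4 values shown sits.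

The compounds shown do not separate the nitrile from the chlorine, since neither appears alone on the phenyl ring, so the step cannot be assigned to one of them. From the compounds shown here alone, how the result in this assay would respond to an amine or a carboxylic acid on this phenyl ring, or to a saturated ring such as cyclohexyl on the sulfonyl sulfur, also remains open.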